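The compounds below may be only part of what the source reports. "The series", "measured", "known", "first", "only" and "open" are said of these compounds alone.

In a functional assay on CCRF-CEM cells (Homo sapiens) for cytotoxicity, in the presence of a further agent that is not named here (on this read-out higher numbers stand for weaker inhibition and lower numbers for stronger inhibition), compound 1 `COC(=O)c1ccc(CN(CCCc2c(N)nc(N)nc2O)c2cc(F)c([N+](=O)[O-])cc2[N+](=O)[O-])cc1` gives 3500 nM. Compound 2 `COC(=O)c1ccc(CN(CCCc2c(N)nc(N)nc2O)c2ccc([N+](=O)[O-])c(F)c2F)cc1` gives 45000 nM in this assay, the highest number of the three measured compounds, and the difference between the core of compound 1 and the core of compound 2 is not broken down here. Compound 3 `Nc1nc(N)c(CCCNc2cc(F)c([N+](=O)[O-])cc2[N+](=O)[O-])c(O)n1` gives 1200 nM in this assay.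

Compound 1 and compound 3 differ in one place: hydrogen in place of 4-(methoxycarbonyl)benzyl on a nitrogen on an aromatic ring. This change made a step of a 2.9-fold lower number from compound 1 to compound 3 (0.46 log units; beyond the scatter) in this assay, a modest but clear move toward stronger inhibition.

The same change, (hydrogen in place of 4-(methoxycarbonyl)benzyl on a nitrogen on an aromatic ring), carries compound 2 to compound 4 `Nc1nc(N)c(CCCNc2ccc([N+](=O)[O-])c(F)c2F)c(O)n1`, which is yet to be measured in this assay. The place of the change is the same in both pairs, a nitrogen on an aromatic ring whose other neighbours are an aromatic carbon and a saturated chain carbon, so this is the same change, seen twice among these compounds. Among the compounds with values here, its size is known from only one measured pair, and the core of compound 2 is not the core of compound 1, so the step from compound 2 to compound 4 is expected to be of similar direction but is uncertain in size. On this basis compound 4 is expected to show a step of a 3.0-fold lower number from compound 2 to compound 4 (0.48 log units; beyond the scatter) in this assay, resting on the step of a 2.9-fold lower number from compound 1 to compound 3 (0.46 log units; beyond the scatter). Compound 4 is therefore estimated at 15000 nM in this assay, with a range from 5000 nM to 45000 nM.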

Compound 4, half-maximal inhibitory concentration: 73000 nM
Estimate against measurement, compound 4: 4.9-fold (0.69 log units) below; the whole stated range lies below it.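

In this assay, hydrogen in place of 4-(methoxycarbonyl)benzyl on the nitrogen made a step of a 1.6-fold higher number from compound 2 to compound 4 (0.21 log units; within the scatter), so on this core the change produces no clear move, whereas on the core of compound 1 it gave a modest move toward stronger inhibition. The change therefore does not carry over from one core to the other with the same outcome: the same change on two cores in this assay, a 2.9-fold lower number (0.46 log units; beyond the scatter) from compound 1 to compound 3 and a 1.6-fold higher number (0.21 log units; within the scatter) from compound 2 to compound 4, 4.7-fold (0.67 log units) apart, beyond the scatter of two such steps. This shows that, among these compounds, the result of the change depends on the core it is made on, but with only one pair per core it does not show which difference between the cores matters, or what the change would do on a third core.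

The compounds shown leave open whether a plain benzyl or a methyl on that nitrogen, or a benzyl carrying a carboxylic acid in place of the methyl ester, would also give different outcomes on the two cores. They also leave open whether the same disagreement would appear with a shorter or longer chain joining that nitrogen to the rest of the shared structure.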